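The source may report more compounds than this note shows. Statements on the series, on what has been measured and on what is new or still open speak of the compounds shown alone.

Measured compounds:
compound 1, `O=C(O)c1cccc(CNc2cc(C(F)(F)F)cc3[nH]ncc23)c1`, giving 17%
compound 2, `Cc1ccc(CNc2cc(C(F)(F)F)cc3[nH]ncc23)c([N+](=O)O)c1`, giving 62%

In an assay for inhibition of Indoleamine 2,3-dioxygenase 1 (Homo sapiens), with stated times of 10 min and 60 min, tested at 100 uM (on this read-out higher numbers stand for a stronger effect at the one concentration tested and lower numbers for a weaker effect), compound 2 stands highest of the two numbers; compound 1 sits well below it, a gap beyond the usual scatter of repeated measurements. Compound 3, `CS(=O)(=O)c1ccc(CNc2cc(C(F)(F)F)cc3[nH]ncc23)c([N+](=O)O)c1`, differs from compound 2 in one place: methylsulfonyl in place of methyl on an aromatic carbon. Among the measured compounds shown here, no measured pair shows this change, so its effect is unknown. A modest drop is expected from compound 2 to compound 3, with a number 12 percentage points lower from compound 2 to compound 3 (beyond the scatter) being the estimated step. For compound 3 the estimated result in this assay is 50%, within a range from 25% to 75%.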

Compound 3, a percentage reported as inhibition, at one concentration (the size of the read-out at that concentration, not a potency): 93%
Compound 3: middle estimate off by 43 percentage points, on the low side; measured number outside the range, above it.
By their numbers in this assay, from the lowest: compound 1; then compound 2; then compound 3.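

In this assay, methylsulfonyl in place of methyl on this aromatic carbon gives a large rise, a number 31 percentage points higher from compound 2 to compound 3 (beyond the scatter), and the rise lies beyond the scatter. The position, para to a large group, therefore accepts a group with more heavy atoms and two hydrogen-bond acceptors, with no loss of the read-out. Nothing measured here explains this gain.

One change cannot show whether the sulfur, the oxygens or the added bulk matters. A nitrile or an ethyl group at this position would help separate these.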